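Chloro for Fluoro on Two Related Cores

The compounds below may be only part of what the source reports. "The series", "measured", "known", "first", "only" and "open" are said of these compounds alone.

Compound 1 `O=C(N/N=C/c1cc(I)cc(I)c1O)c1ccc(F)cc1` and compound 2 `O=C(N/N=C/c1cc(I)cc(I)c1O)c1ccc(Cl)cc1` share one core; compound 3 `O=C(NNCc1cc(I)cc(I)c1O)c1ccc(F)cc1` and the unmeasured compound 4 `O=C(NNCc1cc(I)cc(I)c1O)c1ccc(Cl)cc1` share another. The difference between the two cores is not broken down here. In a functional assay on HepG2 cells (Homo sapiens) for cytotoxicity, with a stated time of 24 h (on this read-out higher numbers stand for weaker inhibition and lower numbers for stronger inhibition), compound 1 gives 12100 nM, compound 2 gives 14800 nM and compound 3 gives 52200 nM. Compound 3 carries the highest number of the three, and its gap to each of the other two lies beyond the scatter. The change chloro in place of fluoro on an aromatic carbon produced a 1.2-fold higher number from compound 1 to compound 2 (0.09 log units; within the scatter), so on the first core the two halogens cannot be told apart in this assay.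

The change chloro in place of fluoro on an aromatic carbon is the same change, at the same place, carried onto the second core. Among the measured compounds shown here, with only one earlier instance to rest on, the step from compound 3 to compound 4 in this assay is expected to be a 1.1-fold higher number from compound 3 to compound 4 (0.06 log units; within the scatter), kept close to the earlier step because a 1.2-fold higher number from compound 1 to compound 2 (0.09 log units; within the scatter) was within the scatter. Compound 4 is therefore estimated at 60000 nM in this assay, with a range from 30000 nM to 120000 nM; the upper end allows for the assay reporting only a limit.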

Compound 4, half-maximal inhibitory concentration: 52200 nM
The estimate for compound 4 lay 1.1-fold (0.06 log units) above the measured number; the range from low to high includes it.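

In this assay, chloro in place of fluoro gives no change at the digits printed from compound 3 to compound 4 (within the scatter), and this step agrees with the one seen on the core of compound 1: the same change on two cores in this assay, a 1.2-fold higher number (0.09 log units; within the scatter) from compound 1 to compound 2 and no change at the digits printed (within the scatter) from compound 3 to compound 4, 1.2-fold (0.09 log units) apart, within the scatter of two such steps

On these two cores, then, the change carries over without a step beyond the scatter, and 4-fluorophenyl and 4-chlorophenyl cannot be told apart in this assay on either core. This does not show that the two halogens are interchangeable in general: the comparison rests on one pair per core, at a single place and in a single read-out, and since neither step lies beyond the scatter, it does not test whether a larger effect would also carry from one core to the other.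

Open, from the compounds shown here alone, is whether a group of a different kind at that place, such as methoxy, an amine or a carboxylic acid, would give a step beyond the scatter. Also open, going by these compounds, is whether such a step would have the same size on both cores.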